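This account rests on a few compounds, and the source may have more. Where it says the series, first, only, none or still open, it means among the compounds named here.

Of the compounds shown here, three built on one shared core have been measured in an assay on membranes from Sf9 cells for displacement of a labelled ligand from histamine H2 receptor (Homo sapiens), read by scintillation counting, with a stated time of 60 min; on this read-out higher numbers stand for weaker inhibition and lower numbers for stronger inhibition. Compound 1 `Cc1nc(N)sc1CCCN/C(N)=N/C(=O)NC(C)c1ccccc1F` gives 28.8 nM. Compound 2 `Cc1nc(N)sc1CCCN/C(N)=N/C(=O)NC(C)c1ccc(F)cc1` gives 31.6 nM, and the step of a 1.1-fold higher number from compound 1 to compound 2 (0.04 log units; within the scatter) shows that exchanging one fluorophenyl for another leaves the number essentially unchanged. Compound 3 `Cc1nc(N)sc1CCCN/C(N)=N/C(=O)NC(C)c1cccs1` gives 63.1 nM, the highest of the three numbers; the steps of a 2.2-fold higher number from compound 1 to compound 3 (0.34 log units; beyond the scatter) and a 2.0-fold higher number from compound 2 to compound 3 (0.30 log units; within the scatter) describe how it stands against the two fluorophenyl compounds, one of them just beyond the scatter and the other within it.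

Compound 4 `Cc1nc(N)sc1CCCN/C(N)=N/C(=O)NC(C)c1cccc(F)c1` is the next compound to be measured in this assay. It differs from compound 3 in one place: 3-fluorophenyl in place of thiophen-2-yl on a saturated chain carbon bound to an amide-type nitrogen and a saturated chain carbon. For the measured compounds named here, the steps that bear on this change run the other way, from a fluorophenyl group to the thiophene: a 2.2-fold higher number from compound 1 to compound 3 (0.34 log units; beyond the scatter) and a 2.0-fold higher number from compound 2 to compound 3 (0.30 log units; within the scatter). Returning from the thiophene to a fluorophenyl group should therefore be worth a step of about that size in the lowering direction, and the step of a 1.1-fold higher number from compound 1 to compound 2 (0.04 log units; within the scatter) suggests that the fluorine's place on the ring hardly shifts the outcome. On that basis compound 4 is expected to reach about 32 nM in this assay, somewhere between 15 nM and 70 nM. The expected step is thus a 2.0-fold lower number from compound 3 to compound 4 (0.29 log units; within the scatter).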

Compound 4, inhibition constant: 2.04 nM
For compound 4 the middle estimate is 16-fold (1.20 log units) above the measured one; measured number outside the range, below it.
By their numbers in this assay, from the lowest: compound 4; then compounds 1, 2 and 3 (each within the scatter of the next, the first and the last beyond it).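

In this assay, the place of the fluorine on the phenyl ring turns out to matter greatly, although the first two fluorophenyl compounds gave no sign of this (a 1.1-fold higher number from compound 1 to compound 2 (0.04 log units; within the scatter)). For the compounds shown here, the 3-fluorophenyl group stands well apart from both the 4-fluorophenyl group (a 15-fold lower number from compound 2 to compound 4 (1.19 log units; beyond the scatter)) and the 2-fluorophenyl group (a 14-fold lower number from compound 1 to compound 4 (1.15 log units; beyond the scatter)), and its step against the thiophen-2-yl group (a 31-fold lower number from compound 3 to compound 4 (1.49 log units; beyond the scatter)) shows that this single position can shift the number far more than the earlier compounds suggested, so a fluorophenyl group as such does not bring the gain. Nothing measured here explains why this one ring pattern stands out.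

Still open, on these data alone, is whether the gain depends on fluorine itself or would also appear with another group in the same ring place, such as 3-chlorophenyl or 3-methoxyphenyl, and how an unsubstituted phenyl group would compare. As far as these compounds go, it is also open whether the 3-fluorophenyl group would keep its advantage if the shared core carried a longer chain.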